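Side-chain variation on the shared core, compounds 1 to 4

The source may hold more compounds than are shown below. What is called first, only, known or untested is meant among the compounds shown, and "the series" means these compounds.

Of the compounds shown here, three on the shared core have been measured in an in vitro functional assay on cells for agonist activity at Bombesin receptor subtype-3 (Homo sapiens), read by luminescence and calcium flux; a higher number here means that more compound is needed for the effect, a lower number that less compound is needed. Compound 1 `O=C(O)c1ccccc1-c1ccc(CCc2ncc(CC3CCOCC3)[nH]2)cc1` gives 338 nM. Compound 3 `CCC(C)(C)Cc1c[nH]c(CCc2ccc(-c3ccccc3C(=O)O)cc2)n1` gives 25 nM, and compound 2 `CCCCc1cnc(C(Cc2ccc(-c3ccccc3C(=O)O)cc2)C(C)C)[nH]1` gives 4620 nM. Compound 1 thus stands second highest of the three numbers: its gap to compound 3 and its gap to compound 2 are each beyond the usual scatter and lie in opposite directions, so compound 1 sits in the middle of the measured range.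

Compound 4 `Cc1cccc(Cc2cnc(CCc3ccc(-c4ccccc4C(=O)O)cc3)[nH]2)c1` has not yet been measured. It differs from compound 1 in one place: 3-methylphenyl in place of oxan-4-yl on a saturated chain carbon bound to an aromatic carbon. Among the compounds with values here, no step between two measured compounds covers this exact change, so the expected size rests on the spread of the three values. Where compound 1 carries the oxane-bearing group, compound 3 carries a branched carbon chain. In this assay, within the data shown here, compound 3 gives 25 nM, while compound 1 gives 338 nM; that comparison is the only guide available for a change at this position. On that basis the expected step is a 2.8-fold lower number from compound 1 to compound 4 (0.45 log units; beyond the scatter), downward and of moderate size, beyond the scatter. The estimate for compound 4 in this assay is 120 nM, with a range from 30 nM to 500 nM.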

Compound 4, half-maximal effective concentration: 4310 nM
Estimate against measurement, compound 4: 36-fold (1.56 log units) below, and the stated range ends below it.
By their numbers in this assay, from the lowest: compound 3; then compound 1; then compounds 4 and 2 (each within the scatter of the next).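

Swapping one six-membered ring for another at this position, with 3-methylphenyl in place of oxan-4-yl on a saturated chain carbon bound to an aromatic carbon, gives a 13-fold higher number from compound 1 to compound 4 (1.11 log units; beyond the scatter) in this assay. Within the data shown here, this is the first step read between two compounds that differ in one place, and it is large and beyond the scatter, so the position clearly responds to the identity of the ring and does not accept any six-membered ring equally. The step is a single observation on one pair, and no measurement at hand accounts for its size.

The pair changes several things at once: the ring goes from non-aromatic to aromatic, the ring oxygen is lost and a methyl is added, so it cannot show which of these carries the step. An unsubstituted phenyl would isolate the methyl, a cyclohexyl ring would isolate the oxygen, and a piperidin-4-yl ring, carrying an amine, would show how this position responds to a ring nitrogen in place of that oxygen.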